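This account rests on a few compounds, and the source may have more. Where it says the series, first, only, none or still open, it means among the compounds named here.

Compound 1 `COc1cccc(C(=O)Oc2cc3c(cc2C)[C@@H](C(C)C)CC=C3C)c1` is the reference for this step. In a functional assay on K562 cells (Homo sapiens) for antiproliferative activity, read by sulforhodamine B assay, with a stated time of 48 h, tested at 50 uM (on this read-out higher numbers stand for more inhibition at the one concentration tested (going by the name of the read-out) and lower numbers for less inhibition), compound 1 gives "not active" (no number reported), so no single number places it. Among the compounds with values here, the only number in the set comes from compound 2 `Cc1cc2c(C(C)C)ccc(C)c2cc1OC(=O)c1ccc([N+](=O)[O-])cc1`, which in this assay gives 100%. Compound 3 `CC1=CC[C@H](C(C)C)c2cc(C)c(OC(=O)c3cccc(C)c3)cc21` is the next candidate. methyl in place of methoxy on an aromatic carbon Only compound 1 stands as its comparator, and that one reports no number, so nothing in this assay shows how such a change moves the read-out; no shift beyond the usual scatter is expected from it. Compound 3 is therefore expected to give 20% in this assay, estimated within 0% to 60%.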

Compound 3, a percentage reported as inhibition, at one concentration (the size of the read-out at that concentration, not a potency): "not active" (no number reported)
For compound 3 the study gives words and no number, and the estimate cannot be compared.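

Within the data shown here, compound 1 and compound 3 both carry words and no number, and no step between them can be read. Nothing at hand bears on this result. The compounds shown leave open whether 3-methoxyphenyl to 3-methylphenyl moves the read-out at all.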